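The source may report more compounds than this note shows. Statements on the series, on what has been measured and on what is new or still open speak of the compounds shown alone.

Compound 2 `COc1ccc(Oc2ccc(N3CC(=O)N([C@@H](CC4CCN(C(=O)C(C)C)CC4)c4nc5ccc(C)cc5n4C4CC4)C3=O)cc2)cc1` and compound 1 `Cc1ccc2nc([C@H](CC3CCN(C(=O)C(C)C)CC3)N3C(=O)CN(c4ccc(Oc5ccc(F)cc5)cc4)C3=O)n(C3CC3)c2c1` share one core and differ by a single change: fluoro in place of methoxy on an aromatic carbon. In an ADME assay on Huh-7 cells (Homo sapiens) for cytotoxicity, read by MTT assay (on this read-out higher numbers stand for weaker inhibition and lower numbers for stronger inhibition), compound 2 reaches only the limit of the assay, > 100000 nM. Compound 1 likewise sits at the assay limit, > 100000 nM. The step that the two limits leave unreadable from compound 2 to compound 1 cannot be read because every value shown stands at the limit of > 100000 nM in this assay, at which 3 of the 3 values shown sit. Compound 3 `COc1ccc(Oc2ccc(N3CC(=O)N([C@@H](CC4CCN(C(=O)C(C)C)CC4)c4nc5ccc(F)cc5n4C)C3=O)cc2)cc1` carries a different core; the difference between the two cores is not broken down here. In this assay compound 3 also gives only the limit, > 100000 nM. Compound 4 `CC(C)C(=O)N1CCC(C[C@@H](c2nc3ccc(F)cc3n2C)N2C(=O)CN(c3ccc(Oc4ccc(F)cc4)cc3)C2=O)CC1` is the unmeasured partner of compound 3, made by the same change, (fluoro in place of methoxy on an aromatic carbon); the place is the same word for word. Resting on compound 3 and its limit > 100000 nM, the step that the limit leaves unreadable from compound 3 to compound 4 is expected to be near nothing. Compound 4 is thus estimated at 150000 nM, most likely again only a limit.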

Compound 4, half-maximal inhibitory concentration: > 100000 nM
Compound 4: no number, only a limit; the forecaster's own chance of this, stated with the estimate: 85%; the middle value does not contradict the limit.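

No step can be read from compound 3 to compound 4, because both values are only limits: the limit of > 100000 nM in this assay, at which 4 of the 4 values shown sit. Whether fluoro in place of methoxy changes anything in this assay at all stays open with the compounds shown.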